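Chloropropyl for cyclopropyl on the fused core

The source may hold more compounds than are shown below. What is called first, only, known or untested is meant among the compounds shown, and "the series" means these compounds.

Two compounds have numbers. Compound 1 `O=c1nc2oc(CCCCl)cc2cn1Cc1cn(-c2ccc(F)cc2)nn1` gives 14600 nM in a functional assay on HepG2 cells (Homo sapiens) for antiproliferative activity, read by MTT assay, with a stated time of 72 h; a higher number here means a weaker inhibitor, a lower number a stronger inhibitor. Compound 2 `O=c1nc2oc(C3CC3)cc2cn1Cc1cn(Cc2ccccc2)nn1` gives 49100 nM in this assay, the higher of the two, with compound 1 beyond the scatter below it. Compound 3 `O=c1nc2oc(CCCCl)cc2cn1Cc1cn(Cc2ccccc2)nn1` is not yet measured; it differs from compound 2 by 3-chloropropyl in place of cyclopropyl on an aromatic carbon. For the measured compounds named here, no measured pair shows this change on its own. Compound 1 carries the entering group and gives 14600 nM. On that basis a downward step beyond the scatter is expected, a 2.5-fold lower number from compound 2 to compound 3 (0.39 log units; beyond the scatter). Compound 3 is expected to give 20000 nM, between 7000 nM and 60000 nM.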

Compound 3, half-maximal inhibitory concentration: 27600 nM
Beside the measured number, compound 3's estimate is 1.4-fold (0.14 log units) below it, and the stated range covers the measured number.
By their numbers in this assay, from the lowest: compounds 1, 3 and 2 (each within the scatter of the next, the first and the last beyond it).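

With benzyl held fixed, the change on the aromatic carbon next to the ring oxygen now reads on its own: 3-chloropropyl in place of cyclopropyl gives a 1.8-fold lower number from compound 2 to compound 3 (0.25 log units; within the scatter) in this assay, so this swap does not separate the pair. With 3-chloropropyl held fixed, benzyl in place of 4-fluorophenyl on an aromatic nitrogen gives a 1.9-fold higher number from compound 1 to compound 3 (0.28 log units; within the scatter), which likewise does not separate its pair. No evidence on the cause of either step is available. Open, going by these compounds, is whether an amine, a carboxylic acid or a longer chain at this carbon would give a step beyond the scatter, and whether a plain propyl group would match 3-chloropropyl.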